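The source may report more compounds than this note shows. Statements on the series, on what has been measured and on what is new or still open speak of the compounds shown alone.

For the measured compounds named here, compound 1 `CCC(CC)n1c(-c2ccc(OCc3c(-c4c(Cl)cccc4Cl)noc3C(C)C)cc2)nc2ccc(C(=O)O)cc21` gives 26.5 nM in an assay on isolated protein for agonist activity at Bile acid receptor (Homo sapiens), read by TR-FRET (on this read-out higher numbers stand for an effect only at larger amounts of compound and lower numbers for an effect already at smaller amounts), and holds the highest of the two numbers so far; its nearest neighbour is compound 2 `CC(C)c1onc(-c2c(Cl)cccc2Cl)c1COc1ccc(-c2nc3ccc(C(=O)O)cc3n2-c2ccc(F)cc2)cc1`, which in this assay gives 15.1 nM, a step of a 1.8-fold lower number from compound 1 to compound 2 (0.24 log units; within the scatter). Compound 3 `CCC(CC)n1c(-c2ccc(OCc3c(-c4c(Cl)cccc4Cl)noc3C(C)C)cc2Cl)nc2ccc(C(=O)O)cc21` differs from compound 1 by chloro in place of hydrogen on an aromatic carbon. Going by the values given here, the only measured step concerns a different place in the molecule and does not bear on this change, so no number-based reading of it is possible. The expectation for compound 3 is a step of a 1.1-fold lower number from compound 1 to compound 3 (0.03 log units; within the scatter), not beyond the scatter, with an estimate of 25 nM in the range 10 nM to 60 nM.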

Compound 3, half-maximal effective concentration: 21.6 nM
Compound 3: the middle estimate sits 1.2-fold (0.06 log units) above what was measured, and the stated range covers the measured number.
By their numbers in this assay, from the lowest: compounds 2, 3 and 1 (each within the scatter of the next).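

Chloro in place of hydrogen on an aromatic carbon, ortho to a large group and meta to a large group, gives in this assay a 1.2-fold lower number from compound 1 to compound 3 (0.09 log units; within the scatter) and so shows that this position accepts one chlorine without a step beyond the scatter. The earlier step spoke only to the group on the aromatic nitrogen. Nothing on hand explains this result.

Open, going by these compounds, is whether methoxy, an amine or a nitrile at this position would also stay within the scatter. Also open, on these data alone, is whether chloro here gives the same reading with 4-fluorophenyl in place of pentan-3-yl.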